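A few compounds are considered here, and "the series" means these few. Any claim that something is new, unique, unknown or untested is made for them only; others in the source may bear on it.

Measured so far in an ADME assay on TZM cells (Homo sapiens) for cytotoxicity, read by XTT assay, with a stated time of 4 days; on this read-out higher numbers stand for lower toxicity in this test and lower numbers for higher toxicity in this test:
Compound 1, `Cc1cc(N)cc(C)c1Oc1cc(Nc2ccc(C#N)cc2)c(N)cc1C(F)(F)F`, gives 15800 nM.
Compound 2, `Cc1cc(CCC#N)cc(C)c1Oc1cc(Nc2ccc(C#N)cc2)c(N)cc1C(F)(F)F`, gives only a limit of the assay, > 7100 nM.
Compound 3, `Cc1cc(/C=C/C#N)cc(C)c1Oc1cc(Nc2ccc(C#N)cc2)c(N)cc1C(F)(F)F`, gives 15000 nM.

Of the two plain numbers, compound 3 holds the lower one, but its nearest neighbour is compound 1, and the step of a 1.1-fold lower number from compound 1 to compound 3 (0.02 log units; within the scatter) lies within the usual scatter, so the two cannot be told apart. The third value is a limit: compound 2 is recorded in this assay only as > 7100 nM. Because of the limit of > 7100 nM in this assay, at which 1 of the 3 values shown sits, the steps a step that the limit leaves unreadable from compound 1 to compound 2 and a step that the limit leaves unreadable from compound 2 to compound 3 cannot be sized.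

Compound 4, `Cc1cc(/C=C/C#N)cc(C)c1Oc1cc(Nc2ccc(C#N)cc2)c(N)cc1C(=O)O`, has not yet been measured. Its change from compound 3 is carboxy in place of trifluoromethyl on an aromatic carbon. Among the measured compounds shown here, none of the measured steps touches this place; all three exchange the amino, 2-cyanoethyl or 2-cyanoethenyl group elsewhere in the shared core, so none of them bears directly on the change at hand. The only guide is that no readable change among these compounds has moved the read-out beyond the scatter, and the step from compound 3 to compound 4 is therefore expected to be no change at the digits printed from compound 3 to compound 4 (within the scatter), nothing beyond the scatter. Compound 4 is estimated at 15000 nM, in a range from 6000 nM to 40000 nM.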

Compound 4, half-maximal cytotoxic concentration: 14900 nM
Compound 4: the middle estimate sits 1.0-fold (0.00 log units) above what was measured, within the range that was stated.
By their numbers in this assay, from the lowest: compounds 4, 3 and 1 (each within the scatter of the next).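

In this assay, carboxy in place of trifluoromethyl gives a 1.0-fold lower number from compound 3 to compound 4 (0.00 log units; within the scatter), so at this position, ortho to a large group and para to a (4-cyanophenyl)amino group, the two groups cannot be told apart in this test. Among the compounds shown here, the earlier readable comparison exchanged a group elsewhere in the shared core, so this is the first look at what this place tolerates, and the exchange is not a small one on paper: a group with no hydrogen-bond donor or acceptor leaves, and one with a hydrogen-bond donor and a hydrogen-bond acceptor enters. Nothing measured here gives a reason for this result.

On these data alone, whether other groups at this place, such as a primary amide, a methyl ester or a hydroxymethyl group, would read the same remains open. Also open, as far as these compounds go, is whether the same exchange would read the same when the core carries the amino group of compound 1 instead of the 2-cyanoethenyl group of compound 3.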